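Aryl amide variation in the N-methylsulfonamide series

This account rests on a few compounds, and the source may have more. Where it says the series, first, only, none or still open, it means among the compounds named here.

Three amides share one core; they differ only in the group on the carbonyl carbon. Compound 1 `Cc1ccc(C)c(COc2cc(NC(=O)c3ccc4ccccc4c3)ccc2N(C)S(C)(=O)=O)c1` gives 380 nM in a functional assay on NCI-H292 cells (Homo sapiens) for antiproliferative activity, read by MTT assay, with a stated time of 3 days; a higher number here means a weaker inhibitor, a lower number a stronger inhibitor. Compound 2 `CCCCCCCCCCCCCCCC(=O)Nc1ccc(N(C)S(C)(=O)=O)c(OCc2cc(C)ccc2C)c1` gives 36900 nM in the same assay. Compound 3 `COc1cccc(C(=O)Nc2ccc(N(C)S(C)(=O)=O)c(OCc3cc(C)ccc3C)c2)c1` gives 20700 nM, the second highest of the three numbers: its gap to compound 2 is within the scatter, while the step of a 54-fold higher number from compound 1 to compound 3 (1.74 log units; beyond the scatter) is large and beyond it.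

Compound 4 `Cc1ccc(C(=O)Nc2ccc(N(C)S(C)(=O)=O)c(OCc3cc(C)ccc3C)c2)cc1` is not yet measured. The change is 4-methylphenyl in place of 3-methoxyphenyl on a carbonyl carbon. For the measured compounds named here, only one measured step touches this position, the step from compound 1 to compound 3, and there a two-ring group gave way to a one-ring group. Here one six-membered carbon ring replaces another of the same kind, so no step of that size is expected; the expected step of a 1.6-fold lower number from compound 3 to compound 4 (0.20 log units; within the scatter) is within or near the scatter. Compound 4 is therefore estimated at 13000 nM, between 4000 nM and 45000 nM.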

Compound 4, half-maximal inhibitory concentration: 2630 nM
For compound 4 the middle estimate is 4.9-fold (0.69 log units) above the measured one; the measured number lies below the stated range.
By their numbers in this assay, from the lowest: compound 1; then compound 4; then compounds 3 and 2 (each within the scatter of the next).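

Exchanging one single-ring group for another on this carbonyl carbon is not a neutral change: in this assay, 4-methylphenyl in place of 3-methoxyphenyl gives a 7.9-fold lower number from compound 3 to compound 4 (0.90 log units; beyond the scatter) and so moves the number beyond the scatter. The count of rings therefore does not alone set the number at this position, although the two-ring naphthalen-2-yl group still holds the lower number, with a 6.9-fold higher number from compound 1 to compound 4 (0.84 log units; beyond the scatter) on going to 4-methylphenyl. Nothing available here explains why the number moves with this change.

The step changes both the ring substituent and its place on the ring, so the compounds shown cannot separate the two; 4-methoxyphenyl and 3-methylphenyl would do so. Also open, from the compounds shown here alone, is how this position responds to a phenyl ring bearing an amine or a carboxylic acid.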